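The source may report more compounds than this note shows. Statements on the series, on what has been measured and on what is new or still open speak of the compounds shown alone.

Measured compounds: compound 1 `O=C(O)CCC/C=C\CC1=CCC[C@@H]1NS(=O)(=O)c1ccccc1` gives 2300 nM; compound 2 `Cc1ccc(S(=O)(=O)N[C@H]2CCC=C2CCCCOCC(=O)O)cc1` gives 1900 nM; compound 3 `O=C(O)CCC/C=C\CC1=CCC[C@@H]1NS(=O)(=O)c1ccccc1[N+](=O)[O-]` gives 680 nM in a functional assay on a cell-free system (plasma) for inhibition of thromboxane A2 receptor (Homo sapiens), read by turbidimetry; a lower number here means a stronger inhibitor, a higher number a weaker inhibitor.

Compound 3 stands lowest of the three numbers in this assay, with compound 2 nearest and compound 1 furthest. Compound 4 `Cc1ccc(S(=O)(=O)N[C@H]2CCC=C2C/C=C\CCCC(=O)O)cc1` differs from compound 3 by 4-methylphenyl in place of 2-nitrophenyl on a sulfonyl sulfur. Going by the values given here, the one measured step that bears on this is the addition of the nitro group, which went a 3.4-fold lower number from compound 1 to compound 3 (0.53 log units; beyond the scatter); removing it should give most of that back, and compound 2, which also carries a 4-methylphenyl, sits close to compound 1. A step upward, of about the size seen before, is therefore expected, a 2.6-fold higher number from compound 3 to compound 4 (0.42 log units; beyond the scatter). Compound 4 is estimated at 1800 nM, within 900 nM to 3600 nM.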

Compound 4, half-maximal inhibitory concentration: 250 nM
Estimate against measurement, compound 4: 7.2-fold (0.86 log units) above; the measured number lies below the stated range.
By their numbers in this assay, from the lowest: compound 4; then compound 3; then compounds 2 and 1 (each within the scatter of the next).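

Going by these compounds alone, at the sulfonyl sulfur, 4-methylphenyl in place of 2-nitrophenyl gives a 2.7-fold lower number from compound 3 to compound 4 (0.43 log units; beyond the scatter) in this assay, and a methyl group added on an aromatic carbon gives a 9.2-fold lower number from compound 1 to compound 4 (0.96 log units; beyond the scatter) in the same assay, so nitro is not the only group there that lowers the number. With 4-methylphenyl held constant, the chain also counts: 5-carboxypent-1-en-1-yl in place of 3-(carboxymethoxy)propyl gives a 7.6-fold lower number from compound 2 to compound 4 (0.88 log units; beyond the scatter) on the same read-out. Nothing measured explains these steps.

The compounds shown leave open how a chlorine or a methoxy group on that aromatic ring would compare with methyl. Also open, on these data alone, is how a longer chain ending in the carboxylic acid would fare.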